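Naphthyl for Methoxyphenyl on a Weakly Cytotoxic Series

This account rests on a few compounds, and the source may have more. Where it says the series, first, only, none or still open, it means among the compounds named here.

Compound 1 `COc1ccc(-c2cn(/N=C/c3cc4ccccc4nc3Cl)c(N)n2)cc1` gives 31800 nM in a functional assay on HCT-116 cells (Homo sapiens) for cytotoxicity, read by MTT assay, with a stated time of 48 h; a lower number here means a stronger inhibitor, a higher number a weaker inhibitor.
Compound 2 `Nc1nc(-c2ccc(Cl)cc2)cn1/N=C/c1cc2ccccc2nc1Cl` gives in this assay only the assay limit > 50000 nM.
Compound 3 `COc1ccc(-c2cn(/N=C/c3cc4cc(C)ccc4nc3Cl)c(N)n2)cc1` likewise gives in this assay only the assay limit > 50000 nM.

Compound 3 thus stands at the limit of > 50000 nM in this assay, at which 2 of the 3 values shown sit, with no number of its own. Compound 4 `Cc1ccc2nc(Cl)c(/C=N/n3cc(-c4cccc5ccccc45)nc3N)cc2c1` differs from it by naphthalen-1-yl in place of 4-methoxyphenyl on an aromatic carbon. Neither measured step touches that group: an at least 1.5-fold higher number from compound 1 to compound 2 (0.19 log units; that floor lies within the scatter) and an at least 1.5-fold higher number from compound 1 to compound 3 (0.19 log units; that floor lies within the scatter) both ran toward the limit, each at a floor that lies within the scatter. Both point to a series that sits at or beyond the limit, so compound 4 is expected to stay there, with a step that the limit leaves unreadable from compound 3 to compound 4 as the estimated step. Compound 4 is therefore estimated at 60000 nM, between 20000 nM and 180000 nM.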

Compound 4, half-maximal inhibitory concentration: 5840 nM
Estimate against measurement, compound 4: 10-fold (1.01 log units) above, outside the stated range (below it).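

Naphthalen-1-yl in place of 4-methoxyphenyl gives an at least 8.5-fold lower number from compound 3 to compound 4 (0.93 log units; beyond the scatter) in this assay, the first step shown that lies beyond the scatter. The group on the five-membered aromatic ring can therefore bring a compound of this series off the assay limit. Compound 3 gives only a limit, so the step is a floor and its full size stays unread: the limit of > 50000 nM in this assay, at which 2 of the 4 values shown sit.

On these data alone, whether naphthalen-2-yl or a saturated ring such as cyclohexyl would do the same at this position stays open. So does whether naphthalen-1-yl has the same effect on the core of compound 1, which lacks the methyl.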